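Sulfonyl substituent exchange: phenoxy in place of morpholine

The compounds below may be only part of what the source reports. "The series", "measured", "known", "first", "only" and "open" are said of these compounds alone.

Two members of the series have been run in a functional assay on the whole organism (trachea) with Rattus norvegicus as the target; on this read-out lower numbers stand for smaller maximal responses and higher numbers for larger maximal responses. Compound 1 `CC(C)NS(=O)(=O)c1ccc2c(c1)C(n1ccccc1=O)=CC(C)(C)O2` gives 94.8%, and compound 2 `CC1(C)C=C(n2ccccc2=O)c2cc(S(=O)(=O)N3CCOCC3)ccc2O1` gives 85.1%. Among the compounds with values here, the only step so far, a number 9.7 percentage points lower from compound 1 to compound 2 (within the scatter), is within the scatter, so the two compounds are not separated on this read-out. Compound 2 stands at the lower of the two numbers, with compound 1 nearest, and that gap is within the scatter.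

Compound 3 `CC1(C)C=C(n2ccccc2=O)c2cc(S(=O)(=O)Oc3ccccc3)ccc2O1` is the next compound to be measured. It differs from compound 2 by phenoxy in place of morpholin-4-yl on a sulfonyl sulfur. Within the data shown here, the one measured step, a number 9.7 percentage points lower from compound 1 to compound 2 (within the scatter), is the only precedent for a change on the sulfonyl sulfur, and it did not move the maximal response beyond the scatter. On that basis compound 3 is expected to show a number 2.9 percentage points higher from compound 2 to compound 3 (within the scatter), that is, no shift beyond the scatter. The estimate for compound 3 is 88%, in a range from 70% to 100%.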

Compound 3, largest response reached (Emax), in percent of the reference or control that the assay uses: 86.7%
Estimate against measurement, compound 3: 1.3 percentage points above; the range from low to high includes it.
By their numbers in this assay, from the lowest: compounds 2, 3 and 1 (each within the scatter of the next).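

On the sulfonyl sulfur, phenoxy now joins isopropylamino and morpholin-4-yl, and in this assay the exchange gives a number 1.6 percentage points higher from compound 2 to compound 3 (within the scatter) and, against the secondary sulfonamide, a number 8.1 percentage points lower from compound 1 to compound 3 (within the scatter) with no separation on this read-out. Within the data shown here, none of the steps among the three compounds lies beyond the scatter, so replacing the non-aromatic ring with an aromatic ring of carbon only, or the isopropylamino group with phenoxy, leaves the maximal response unresolved from that of the earlier compounds. No measurement at hand explains this lack of separation.

On these data alone, whether any group on the sulfonyl sulfur can move the maximal response beyond the scatter remains open. A plain amino group, a piperazine or a longer alkyl chain ending in a carboxylic acid would test this, as none of them is among the compounds shown.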